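A few compounds are considered here, and "the series" means these few. Any claim that something is new, unique, unknown or untested is made for them only; others in the source may bear on it.

Measured compounds: compound 1 `O[C@@H]1[C@@H](OCc2ccccc2)[C@H](OCc2ccccc2)[C@@H](COCc2ccccc2)O[C@H]1CC1CCCCC1` with 4100 nM; compound 2 `CCCCCCCCCCCCCCCOC[C@H]1O[C@H](CCC)[C@H](O)[C@@H](OCCCCCCCCCCCCCCC)[C@@H]1OCCCCCCCCCCCCCCC` reported as "not active" (no number reported).

Among the compounds with values here, compound 1 is the only compound of the two with a number in a functional assay on HL-60 cells (Homo sapiens) for antiproliferative activity, read by MTT assay; a lower number here means a stronger inhibitor, a higher number a weaker inhibitor; in that assay compound 1 gives 4100 nM, and compound 2 is reported only as "not active" (no number reported), without a figure, so no step between the two measured compounds can be stated. Compound 1 therefore stands alone as the sole point of reference in this assay.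

Compound 3 `O[C@@H]1[C@@H](OCc2ccccc2)[C@H](OCc2ccccc2)[C@@H](COCc2ccccc2)O[C@H]1c1ccccc1` is the compound not yet measured. It differs from compound 1 in one place: phenyl in place of cyclohexylmethyl on a saturated ring carbon. The two compounds share the same core and the same three benzyloxy-bearing substituents, and only the group on the saturated ring carbon next to the ring oxygen changes.

Within the data shown here, with no measured step of this kind to lean on, the expectation is a modest change, most likely a small loss of activity, so the step from compound 1 to compound 3 is estimated at a 1.6-fold higher number from compound 1 to compound 3 (0.20 log units; within the scatter) in this assay. Compound 3 is accordingly expected to give about 6500 nM, within a range from 1500 nM to 28000 nM.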

Compound 3, half-maximal inhibitory concentration: 26300 nM
Estimate against measurement, compound 3: 4.0-fold (0.61 log units) below, and the stated range covers the measured number.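

In this assay, within the data shown here, the saturated ring carbon next to the ring oxygen proves sensitive to the group it carries: putting phenyl in place of cyclohexylmethyl gives a 6.4-fold higher number from compound 1 to compound 3 (0.81 log units; beyond the scatter) and thus the first readable step in this set, one that lies beyond the usual scatter. Both groups consist of carbon only, with no hydrogen-bond donors or acceptors and no net charge, so activity here shifts with a change confined to the hydrocarbon group while the rest of the molecule stays the same. Nothing in the data at hand explains the loss of activity.

The compounds shown leave open whether the step follows from the aromatic ring or from the loss of the carbon link to the ring, as the two changes arrive together, and a benzyl or a plain cyclohexyl group on this carbon would tell them apart. Among these compounds, also open is how an amine or a carboxylic acid would read at this carbon, and compound 2, reported without a number, offers no further step to read.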